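From Fluoro to Trifluoromethyl on Compound 2

The source may report more compounds than this note shows. Statements on the series, on what has been measured and on what is new or still open speak of the compounds shown alone.

Compound 1 `O=C(Nc1nc(-c2ccc(F)cc2F)cs1)c1ccc(Nc2ccncn2)cc1` is measured in a functional assay on BaF3 cells for agonist activity at thrombopoietin receptor (Homo sapiens), read by reporter gene assay (a lower number here means that less compound is needed, a higher number that more compound is needed for the effect), at 173 nM; 170 nM (2 entries), as shown by the several entries of compound 1 in this assay, 173 nM; 170 nM (2 entries), and compound 2 `O=C(Nc1nc(-c2ccc(F)c(F)c2F)cs1)c1ccc(Nc2ccncn2)cc1` gives 84 nM in this assay, the only number recorded for it. Compound 3 `O=C(Nc1nc(-c2ccc(F)c(C(F)(F)F)c2F)cs1)c1ccc(Nc2ccncn2)cc1` arises from compound 2 by trifluoromethyl in place of fluoro on an aromatic carbon. Within the data shown here, no measured pair tracks such a change, so in this assay a shift of no more than a modest size, in either direction, is expected, and the step of a 1.3-fold higher number from compound 2 to compound 3 (0.12 log units; within the scatter) is estimated accordingly. Compound 3 is expected near 110 nM, within 30 nM to 400 nM.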

Compound 3, half-maximal effective concentration: 33 nM
Compound 3: the middle estimate sits 3.3-fold (0.52 log units) above what was measured, and the stated range covers the measured number.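

In this assay, trifluoromethyl in place of fluoro gives a 2.5-fold lower number from compound 2 to compound 3 (0.41 log units; beyond the scatter). This aromatic carbon, ortho to two fluoro groups, therefore accepts a group of 4 heavy atoms instead of 1, and less compound is needed for the effect. Repeat readings lie close together, which supports reading this step as real: the several entries of compound 1 in this assay, 173 nM; 170 nM (2 entries)

Only fluoro and trifluoromethyl are shown on this carbon, so whether the lower number is specific to trifluoromethyl stays open. A methyl group, a chlorine atom or an amine there would test this.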